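This account rests on a few compounds, and the source may have more. Where it says the series, first, only, none or still open, it means among the compounds named here.

Compound 3 `O=C(Nc1cccc(-c2oc3cc(-c4ccc(F)cc4)ccc3c(=O)c2O)c1)c1cc(F)cc(F)c1` gives the lowest number of the three measured in a functional assay on MCF7 cells (Homo sapiens) for antiproliferative activity, read by CCK-8 assay, with a stated time of 72 h (a lower number here means a stronger inhibitor, a higher number a weaker inhibitor), at 2490 nM. The nearest measured neighbour is compound 1 `O=C(Nc1cccc(-c2oc3cc(-c4ccc(F)cc4)ccc3c(=O)c2O)c1)c1ccc(F)cc1F`, which in this assay gives 13500 nM; compound 2 `COc1ccc(C(=O)Nc2cccc(-c3oc4cc(-c5ccc(F)cc5)ccc4c(=O)c3O)c2)c(F)c1` gives 20000 nM. Both neighbours differ from compound 3 only in the aryl group on the carbonyl carbon: a 5.4-fold lower number from compound 1 to compound 3 (0.73 log units; beyond the scatter) and an 8.0-fold lower number from compound 2 to compound 3 (0.90 log units; beyond the scatter). Between those two neighbours the change of methoxy for fluoro gave a 1.5-fold higher number from compound 1 to compound 2 (0.17 log units; within the scatter).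

Compound 4 `CCCc1ccc(C(=O)Nc2cccc(-c3oc4cc(-c5ccc(F)cc5)ccc4c(=O)c3O)c2)cc1` differs from compound 3 by 4-propylphenyl in place of 3,5-difluorophenyl on a carbonyl carbon. Among the measured compounds shown here, no measured pair covers a propyl chain in this position, so the only bearing comes from the two steps above, which show that the choice of aryl on the carbonyl carbon moves this assay by a modest amount, with the 3,5-difluorophenyl giving the lowest number seen. A 4-propylphenyl is a different substitution pattern from all three measured aryls, and the precedent of compounds 1 and 2 points to a higher number than compound 3 for such a departure. For compound 4 the expected step is therefore a 3.2-fold higher number from compound 3 to compound 4 (0.51 log units; beyond the scatter), a modest rise. The estimate for compound 4 in this assay is 8000 nM, with a range from 2000 nM to 30000 nM.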

Compound 4, half-maximal inhibitory concentration: 36800 nM
Compound 4: middle estimate off by 4.6-fold (0.66 log units), on the low side; measured number above the stated range.
By their numbers in this assay, from the lowest: compound 3; then compounds 1, 2 and 4 (each within the scatter of the next, the first and the last beyond it).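

In this assay, among the compounds shown here, the aryl group on the carbonyl carbon proves able to produce a large change and not only a modest one: a 15-fold higher number from compound 3 to compound 4 (1.17 log units; beyond the scatter) is the largest step so far. Compound 3 now stands further apart from the other three, with a 1.8-fold higher number from compound 2 to compound 4 (0.26 log units; within the scatter) leaving 4-propylphenyl and 2-fluoro-4-methoxyphenyl indistinguishable here, a 2.7-fold higher number from compound 1 to compound 4 (0.44 log units; beyond the scatter) separating 4-propylphenyl from 2,4-difluorophenyl, and 3,5-difluorophenyl remaining the only group of the four without a substituent numbered 4 in its name, an association that no compound shown goes against. No measurement is available that accounts for these differences.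

The compounds shown do not separate the presence of the two fluorines named in 3,5-difluorophenyl from the absence of a substituent numbered 4, a question that an unsubstituted phenyl, a 3-fluorophenyl or a 3,5-dimethoxyphenyl on the same carbonyl carbon would address. From the compounds shown here alone, it also remains open how a 4-ethylphenyl, a longer chain, a 4-aminophenyl or a 4-carboxyphenyl would compare with 4-propylphenyl.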